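Methyl on the Ring Nitrogen of Compound 1

This account rests on a few compounds, and the source may have more. Where it says the series, first, only, none or still open, it means among the compounds named here.

Compound 1 `COc1cc(/C=C\c2ccc3[nH]ccc3c2)cc(OC)c1`: 200 nM
Compound 2 `COc1cc(/C=C\c2ccc3cc[nH]c3c2)cc(OC)c1`: 200 nM
Compound 3 `COc1cc(/C=C\c2ccc3[nH]cnc3c2)cc(OC)c1`: 800 nM

All three compounds were tested in a functional assay on MIA PaCa-2 cells (Homo sapiens) for cytotoxicity, read by resazurin assay, with a stated time of 48 h; on this read-out lower numbers stand for stronger inhibition and higher numbers for weaker inhibition. There, compound 1 at 200 nM stands level with compound 2 at 200 nM, and the two lie within the usual scatter of repeat measurements. Compound 3 gives a clearly higher number, 800 nM, so compound 1 is at the stronger end of this small set.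

Compound 4 `COc1cc(/C=C\c2ccc3c(ccn3C)c2)cc(OC)c1` has not yet been measured. It differs from compound 1 by methyl in place of hydrogen on an aromatic nitrogen. Among the compounds with values here, no measured pair shows this change on its own, so the expectation is a judgement with a wide range. A small move toward a higher number, meaning weaker inhibition, seems most likely, and it may not clear the scatter. The expected size is a 1.5-fold higher number from compound 1 to compound 4 (0.18 log units; within the scatter). For compound 4 the estimated value is 300 nM, with an expected range from 100 nM to 900 nM.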

Compound 4, half-maximal inhibitory concentration: 80 nM
Compound 4: middle estimate off by 3.8-fold (0.57 log units), on the high side; the measured number lies below the stated range.
By their numbers in this assay, from the lowest: compound 4; then compounds 1 and 2 (each within the scatter of the next); then compound 3.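

In this assay, replacing the hydrogen on the aromatic nitrogen with methyl gives a 2.5-fold lower number from compound 1 to compound 4 (0.40 log units; beyond the scatter), a modest step but one beyond the scatter. This shows that the hydrogen on this nitrogen of compound 1 is not required for the effect on these cells. The position accepts a methyl group, and the number moves in the stronger direction rather than the weaker one. Nothing available here explains this step.

As far as these compounds go, it remains open whether the gain continues, stays level or reverses with a larger group on this nitrogen, such as ethyl, a longer chain or a chain ending in an amine. From the compounds shown here alone, it is also open whether the same methyl change would shift the numbers of compound 2 and compound 3 in the same direction.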